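Triazole substituent swap on a chromene ester

A few compounds are considered here, and "the series" means these few. Any claim that something is new, unique, unknown or untested is made for them only; others in the source may bear on it.

Measured compounds: compound 1 `CCOC(=O)C1=Cc2ccccc2OC1(OCc1cn(CC(=O)Nc2cccc(Cl)c2)nn1)C(F)(F)F` with 12800 nM in a functional assay on A549 cells (Homo sapiens) for inhibition, read by MTT assay, with a stated time of 24 h; a lower number here means a stronger inhibitor, a higher number a weaker inhibitor; compound 2 `O=C(O)C1=Cc2ccccc2OC1(OCc1cc(-c2ccc([N+](=O)[O-])cc2)no1)C(F)(F)F` with > 150000 nM as a limit of this assay.

Among the measured compounds shown here, compound 1 holds the only number given; the other value shown is the limit (the limit of > 150000 nM in this assay, at which 1 of the 2 values shown sits). Compound 3 `CCOC(=O)C1=Cc2ccccc2OC1(OCc1cn(-c2ccc(F)c([N+](=O)[O-])c2)nn1)C(F)(F)F` is not yet measured. It differs from compound 1 by 4-fluoro-3-nitrophenyl in place of ((3-chlorophenyl)carbamoyl)methyl on an aromatic nitrogen. For the measured compounds named here, with no measured step of this kind, a change only within the usual scatter is expected in this assay. Compound 3 is expected at 15000 nM, between 4000 nM and 60000 nM. The expected step of a 1.2-fold higher number from compound 1 to compound 3 (0.07 log units; within the scatter) is small.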

Compound 3, half-maximal inhibitory concentration: 11900 nM
Estimate against measurement, compound 3: 1.3-fold (0.10 log units) above; the measured number falls inside the stated range.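

Among the compounds shown here, the step at the aromatic nitrogen, a 1.1-fold lower number from compound 1 to compound 3 (0.03 log units; within the scatter), is the first comparison in this assay between compounds that differ in one place. This position accepts 4-fluoro-3-nitrophenyl in place of ((3-chlorophenyl)carbamoyl)methyl with no change beyond the scatter, so in this pair neither the amide hydrogen nor the carbamoyl link is needed to hold this level of inhibition. Nothing measured here accounts for this result.

Open, on these data alone, is whether a small group such as methyl, or a chain ending in an amine, on the same nitrogen would hold this level.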